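Notes on an ethynyl to ethyl swap in the series

The compounds below may be only part of what the source reports. "The series", "measured", "known", "first", "only" and "open" are said of these compounds alone.

Measured so far:
compound 1, `Cc1cccc(Nc2nc(-c3ccncc3CCCO)cs2)c1`: 6920 nM
compound 2, `C#Cc1cnccc1-c1csc(Nc2cccc(C)c2)n1`: 1380 nM

In a functional assay on RCC4 cells (Homo sapiens) for inhibition, read by XTT assay, with a stated time of 4 days (on this read-out lower numbers stand for stronger inhibition and higher numbers for weaker inhibition), compound 1 gives 6920 nM and compound 2 gives 1380 nM. For the measured compounds named here, the one step covered so far, a 5.0-fold lower number from compound 1 to compound 2 (0.70 log units; beyond the scatter), shows that the exchange of the 3-hydroxypropyl for ethynyl moved the number clearly downward. Going by the values given here, compound 2 therefore holds the lowest of the two numbers, with compound 1 as its only neighbour, set apart by a gap beyond the scatter.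

Compound 3, `CCc1cnccc1-c1csc(Nc2cccc(C)c2)n1`, differs from compound 2 by ethyl in place of ethynyl on an aromatic carbon. Among the compounds with values here, no measured step bears directly on a saturated two-carbon chain at that position; the only step known, a 5.0-fold lower number from compound 1 to compound 2 (0.70 log units; beyond the scatter), concerns a longer chain carrying a hydroxyl and is of modest size. With the triple bond gone but the chain kept short, the number for compound 3 is expected to drift somewhat upward from compound 2, an expected step of a 1.8-fold higher number from compound 2 to compound 3 (0.26 log units; within the scatter), smaller than the step that separates compound 1 from compound 2. The estimate for compound 3 in this assay is 2500 nM, with a range from 800 nM to 8000 nM.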

Compound 3, half-maximal inhibitory concentration: 6310 nM
The estimate for compound 3 lay 2.5-fold (0.40 log units) below the measured number; low and high end bracket the measured number.
By their numbers in this assay, from the lowest: compound 2; then compounds 3 and 1 (each within the scatter of the next).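

At this place, on an aromatic carbon of a six-membered aromatic ring with 1 nitrogen and two atoms from the ring nitrogen, the short length of the chain does not by itself hold the lower number of compound 2: in this assay, ethyl in place of ethynyl gives a 4.6-fold higher number from compound 2 to compound 3 (0.66 log units; beyond the scatter). Among the compounds shown, the lower number appears only with the triple bond, while the two saturated chains read alike, with hydrogen in place of hydroxymethyl giving a 1.1-fold lower number from compound 1 to compound 3 (0.04 log units; within the scatter). No measurement on hand accounts for either step.

Still open, as far as these compounds go, is whether the triple bond itself is what counts, a question that a nitrile, a vinyl group or a propynyl group at this place would address. The compounds shown also leave open how a short hydroxymethyl group, or an amine at the end of a saturated chain, would read against the ethyl of compound 3.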